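Benzylamide and phenyl swaps on the fused amidine core

A few compounds are considered here, and "the series" means these few. Any claim that something is new, unique, unknown or untested is made for them only; others in the source may bear on it.

compound 1 `O=C(O)CC1c2ccccc2N=C(N2CCOCC2)N1c1ccccc1`: 9%
compound 2 `O=C(O)CC1c2ccccc2N=C(c2ccccc2)N1c1ccccc1`: 7.2%
compound 3 `O=C(CC1c2ccccc2N=C(N2CCOCC2)N1c1ccccc1)NCc1ccccc1`: 63.8%

All three were tested in a functional assay on cells (Oocyte) for inhibition of Voltage-dependent T-type calcium channel subunit alpha-1H (Homo sapiens), tested at 100 uM; on this read-out higher numbers stand for more inhibition at the one concentration tested (going by the name of the read-out) and lower numbers for less inhibition. The change phenyl in place of morpholin-4-yl on a carbon with a double bond to nitrogen gave the step of a number 1.8 percentage points lower from compound 1 to compound 2 (within the scatter), so compound 1 and compound 2 read alike in this assay. The change benzylamino in place of hydroxy on a carbonyl carbon gave the step of a number 54.8 percentage points higher from compound 1 to compound 3 (beyond the scatter), the largest movement in the series. Compound 4 `O=C(CC1c2ccccc2N=C(c2ccccc2)N1c1ccccc1)NCc1ccccc1` is not yet measured; it carries the change phenyl in place of morpholin-4-yl on a carbon with a double bond to nitrogen relative to compound 3. This is the same kind of change as from compound 1 to compound 2, though the place differs in one detail: there the ring atom two ring bonds away bears a carboxymethyl group, here it bears a (benzylcarbamoyl)methyl group. Given the small step seen in a number 1.8 percentage points lower from compound 1 to compound 2 (within the scatter), compound 4 is expected to give a step of a number 8.8 percentage points lower from compound 3 to compound 4 (within the scatter), with added uncertainty because compound 3 sits at 63.8%, a far higher starting point than compound 1 had. Compound 4 is estimated at 55%.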

Compound 4, a percentage reported as inhibition, at one concentration (the size of the read-out at that concentration, not a potency): 14.8%
Compound 4: the middle estimate sits 40.2 percentage points above what was measured; the measured number lies below the stated range.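

In this assay the change to phenyl from morpholin-4-yl does not carry from one core to the other, with a number 49 percentage points lower from compound 3 to compound 4 (beyond the scatter) standing apart from the earlier step: the same change on two cores in this assay, a number 1.8 percentage points lower (within the scatter) from compound 1 to compound 2 and a number 49 percentage points lower (beyond the scatter) from compound 3 to compound 4, 47.2 percentage points apart, beyond the scatter of two such steps

The change to benzylamino from hydroxy does not carry either, with a number 7.6 percentage points higher from compound 2 to compound 4 (within the scatter) on the phenyl core: the same change on two cores in this assay, a number 54.8 percentage points higher (beyond the scatter) from compound 1 to compound 3 and a number 7.6 percentage points higher (within the scatter) from compound 2 to compound 4, 47.2 percentage points apart, beyond the scatter of two such steps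

The two changes are therefore not additive across these four compounds, with only compound 3 reading high, but this single-concentration read-out gives no potency and no reason for the dependence.

Open, as far as these compounds go, is whether another amine on that carbon, such as piperidine or dimethylamino, behaves like morpholin-4-yl. Also open, from the compounds shown here alone, is whether a phenethylamino group in place of benzylamino keeps the reading of compound 3.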